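Swapping a cyclopentyl for a neopentyl on the ether chain

This account rests on a few compounds, and the source may have more. Where it says the series, first, only, none or still open, it means among the compounds named here.

Of the compounds shown here, three have been tested in a functional assay on NCI-H23 cells (Homo sapiens) for antiproliferative activity, read by sulforhodamine B assay; on this read-out lower numbers stand for stronger inhibition of growth and higher numbers for weaker inhibition of growth. Compound 1 `COc1cccc(OCCC(C)(C)C)c1C(=O)/C=C/c1ccc(O)cc1` gives > 30000 nM in this assay, which is a limit and not a number. Compound 2 `O=C(/C=C/c1ccc(O)cc1)c1c(O)cccc1OCc1ccccc1` also gives > 30000 nM in this assay, again a limit. Going by the values given here, compound 3 `O=C(/C=C/c1ccc(O)cc1)c1c(O)cccc1OCC1CCCC1` gives 3160 nM in this assay, the only measured number among the three. The values of compound 1 and compound 2 are limits, as the limit of > 30000 nM in this assay, at which 2 of the 3 values shown sit, notes. Among the compounds with values here, the one step that can be read, an at least 9.4-fold lower number from compound 2 to compound 3 (0.97 log units; beyond the scatter), shows that a change at the ether chain can move the read-out well beyond the scatter.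

Compound 4 `CC(C)(C)CCOc1cccc(O)c1C(=O)/C=C/c1ccc(O)cc1` differs from compound 3 by neopentyl in place of cyclopentyl on a saturated chain carbon bound to an oxygen on an aromatic ring. Within the data shown here, no measured step covers this exact change. Compound 1 carries the same 3,3-dimethylbutoxy chain as compound 4 but differs from it elsewhere on the core, and it sits at a limit, whereas compound 3 gives a number. Among the measured compounds shown here, the only comparable step, from compound 2 to compound 3, went toward stronger inhibition when a ring was exchanged, so moving from a ring to an open chain is expected to cost rather than gain. Compound 4 is therefore estimated at 8000 nM, within 2000 nM to 30000 nM, an expected step of a 2.5-fold higher number from compound 3 to compound 4 (0.40 log units; beyond the scatter).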

Compound 4, concentration for 50% growth inhibition: 3130 nM
Estimate against measurement, compound 4: 2.6-fold (0.41 log units) above; the measured number falls inside the stated range.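

The ring itself turns out not to be needed at this place on the ether chain: exchanging cyclopentyl for neopentyl gives a 1.0-fold lower number from compound 3 to compound 4 (0.00 log units; within the scatter), so here an open chain and a saturated ring cannot be told apart on this read-out. Phenyl now stands apart from two saturated groups rather than from one, with an at least 9.5-fold lower number from compound 2 to compound 4 (0.98 log units; beyond the scatter), while the free hydroxyl on the core proves to matter as well, since hydrogen in place of methyl on that oxygen, with the 3,3-dimethylbutoxy chain kept, gives an at least 9.5-fold lower number from compound 1 to compound 4 (0.98 log units; beyond the scatter). The second and third of these steps start from compound 2 and compound 1, which sit at a limit and not at a number, so they give only a minimum size: the limit of > 30000 nM in this assay, at which 2 of the 4 values shown sit.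

The compounds shown do not tell how far the tolerance for saturated groups extends, for example to a longer chain or to a chain ending in an amine or a carboxylic acid. As far as these compounds go, it also remains open whether methyl on that oxygen would have the same effect with the cyclopentylmethoxy chain as with the 3,3-dimethylbutoxy chain.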